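Adding a methoxy to compound 2

The compounds below may be only part of what the source reports. "The series", "measured", "known", "first", "only" and "open" are said of these compounds alone.

Compound 1 `Fc1ccccc1C[C@H]1COC[C@@H]1Cc1ccc(Cl)c(Cl)c1` gives 51000 nM
Compound 2 `Oc1cccc(C[C@H]2COC[C@@H]2Cc2ccc(Cl)c(Cl)c2)c1` gives 31000 nM

Both numbers come from a functional assay on HL-60 cells (Homo sapiens) for cytotoxicity, read by WST assay, with a stated time of 48 h (a lower number here means that less compound is needed, a higher number that more compound is needed for the effect), and cannot be told apart within the usual scatter, so compound 2 stands level with compound 1. Compound 3 `COc1ccc(C[C@H]2COC[C@@H]2Cc2ccc(Cl)c(Cl)c2)cc1O` differs from compound 2 by methoxy in place of hydrogen on an aromatic carbon in one place: methoxy in place of hydrogen on an aromatic carbon, ortho to a hydroxy group and para to a large group. Within the data shown here, the only measured step, a 1.6-fold lower number from compound 1 to compound 2 (0.22 log units; within the scatter), also alters a group on an aromatic ring, but no measured compound carries a methoxy. In this assay the expected change is therefore none beyond the scatter, with no firm direction, and the estimated step is a 1.1-fold lower number from compound 2 to compound 3 (0.06 log units; within the scatter) as a best guess. For compound 3 the estimated value is 27000 nM with an expected range from 11000 nM to 65000 nM.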

Compound 3, half-maximal effective concentration: 33000 nM
Beside the measured number, compound 3's estimate is 1.2-fold (0.09 log units) below it, and the stated range covers the measured number.
By their numbers in this assay, from the lowest: compounds 2, 3 and 1 (each within the scatter of the next).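

In this assay the methoxy added to the aromatic ring, ortho to a hydroxy group and para to a large group, shows a 1.1-fold higher number from compound 2 to compound 3 (0.03 log units; within the scatter) and so leaves the number level. Compound 3 is the first compound shown with a methoxy, and at this position that group brings no change that can be told from the scatter. Nothing measured here offers an explanation for this result. Going by these compounds, whether an amine or a carboxylic acid at this same place would shift the number remains open, as does whether a methoxy elsewhere on this ring would leave it level.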